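A few compounds are considered here, and "the series" means these few. Any claim that something is new, unique, unknown or untested is made for them only; others in the source may bear on it.

Of the compounds shown here, two have numbers so far. Compound 1 `CN(C)c1nc2c(Cl)cc(Cl)cc2n1COC(CO)CO` carries a dimethylamino group on the shared core. In a functional assay on KB cells (Homo sapiens) for inhibition (on this read-out lower numbers stand for stronger inhibition and higher numbers for weaker inhibition), compound 1 is reported only as a limit, > 100000 nM. Compound 2 `CN(C)c1nc2c(Cl)c(Cl)ccc2n1COC(CO)CO` is the other tested member. In this assay compound 2 likewise stops at a limit, > 100000 nM. Both values therefore sit at the same limit (the limit of > 100000 nM in this assay, at which 2 of the 2 values shown sit), and compound 1 stands nowhere in an order: it is one of two compounds without a measured number, and nothing separates the pair.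

Compound 3 `OCC(CO)OCn1c(S)nc2c(Cl)cc(Cl)cc21` is the next candidate. Relative to compound 1 the change is sulfanyl in place of dimethylamino on an aromatic carbon, in words sulfanyl in place of dimethylamino on an aromatic carbon. For the measured compounds named here, no measured step of this kind exists, and with both tested compounds at the limit there is no measured direction to follow. The expected step in this assay is a step that the limit leaves unreadable from compound 1 to compound 3, which is to say none beyond the scatter. Compound 3 is accordingly expected to give about 150000 nM in this assay, within a range from 30000 nM to 1000000 nM, and most probably only a limit once more.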

Compound 3, half-maximal inhibitory concentration: > 100000 nM
Compound 3: only a limit was reported; the forecaster's own chance of this, stated with the estimate: 80%; the middle value does not contradict the limit.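

In this assay compound 3 gives > 100000 nM as a limit and not a number. No step from compound 1 to compound 3 can be read, because both stop at the same limit: the limit of > 100000 nM in this assay, at which 3 of the 3 values shown sit.

The compounds shown leave open whether any member of the series reaches a measurable value in this assay and whether sulfanyl in place of dimethylamino on an aromatic carbon changes inhibition at all.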